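Swapping the aryl ketone end: a predicted chalcone analogue

The compounds below may be only part of what the source reports. "The series", "measured", "known", "first", "only" and "open" are said of these compounds alone.

Measured so far:
- compound 1 `COc1ccc(-c2cc(/C=C/C(=O)c3ccc(N)cc3)[nH]n2)cc1`, a functional assay on RPMI-8226 cells (Homo sapiens) for cytotoxicity, read by sulforhodamine B assay, with a stated time of 48 h, tested at 0.01 uM; a lower number here means a stronger effect, a higher number a weaker effect of the compound at the concentration tested: 99%
- compound 2 `COc1cc(-c2cc(/C=C/C(=O)c3ccc(Cl)c(Cl)c3)[nH]n2)cc(OC)c1OC`, this assay: 100%

In this assay compound 2 gives 100%, and compound 1 gives 99%. The two values lie within the usual scatter of each other, so at this concentration neither compound shows a cytotoxic effect that can be told apart from the other; both leave the cells essentially untouched.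

Compound 3 `COc1ccc(C(=O)/C=C/c2cc(-c3cc(OC)c(OC)c(OC)c3)n[nH]2)cc1` has not yet been measured in this assay. It differs from compound 2 in one place: 4-methoxyphenyl in place of 3,4-dichlorophenyl on a carbonyl carbon. The rest of the molecule, including the shared core with its trimethoxyphenyl side, is unchanged.

Among the measured compounds shown here, with no measured step of this kind available, the only guide is that both measured compounds sit near full activity, that is, near no effect. The step from compound 2 to compound 3 is expected to be small, within the scatter, as a number 2 percentage points lower from compound 2 to compound 3 (within the scatter). For compound 3 the estimate in this assay is therefore 98%, with a range from 88% to 104%.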

Compound 3, a percentage reported as activity, at one concentration (the size of the read-out at that concentration, not a potency): 98%
Estimate against measurement, compound 3: no gap at the digits printed; the measured number falls inside the stated range.
By their numbers in this assay, from the lowest: compounds 3, 1 and 2 (each within the scatter of the next).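

In this assay, putting 4-methoxyphenyl in place of 3,4-dichlorophenyl on a carbonyl carbon gives a number 2 percentage points lower from compound 2 to compound 3 (within the scatter). Among the compounds shown here, this is the first pair that differs in only one place, so it offers the first direct reading of this position: two chlorine atoms leave, one oxygen and one hydrogen-bond acceptor enter, and the read-out does not tell the two compounds apart. With both compounds close to no effect at the single concentration tested, the pair gives no sign that this exchange matters at that concentration, and no measurement shown here bears on the reason for this result.

From the compounds shown here alone, it remains open whether compound 2 and compound 3 would separate at a higher concentration, where a cytotoxic effect might become visible at all. Going by these compounds, it is also open whether a carboxylic acid or a longer chain in place of the 4-methoxyphenyl on a carbonyl carbon would move the read-out away from near no effect, with the rest of compound 3 kept unchanged.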